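Butyl in Place of 4-Bromophenyl: Expected Cytotoxicity

The compounds below may be only part of what the source reports. "The series", "measured", "known", "first", "only" and "open" are said of these compounds alone.

Compound 1 `COc1ccc(-c2cn(C[C@H](O)[C@H]3OC(=O)C(OCc4ccccc4)=C3OCc3ccccc3)nn2)cc1`: in an ADME assay on HFF cells (Homo sapiens) for cytotoxicity, read by MTT assay, with a stated time of 72 h (on this read-out higher numbers stand for weaker inhibition and lower numbers for stronger inhibition), compound 1 gives < 10 nM, a limit of the assay.
Compound 2 `O=C1O[C@H]([C@@H](O)Cn2cc(C3CC3)nn2)C(OCc2ccccc2)=C1OCc1ccccc1`: compound 2 gives 24300 nM.
Compound 3 `O=C1O[C@H]([C@@H](O)Cn2cc(-c3ccc(Br)cc3)nn2)C(OCc2ccccc2)=C1OCc1ccccc1`: compound 3 gives 5100 nM.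

Compound 3 holds the lowest of the two numbers shown; its nearest neighbour is compound 2, set apart by a 4.8-fold lower number from compound 2 to compound 3 (0.68 log units; beyond the scatter). The value of compound 1 is a limit (the limit of < 10 nM in this assay, at which 1 of the 3 values shown sits).

Compound 4 `CCCCc1cn(C[C@H](O)[C@H]2OC(=O)C(OCc3ccccc3)=C2OCc2ccccc2)nn1` differs from compound 3 by butyl in place of 4-bromophenyl on an aromatic carbon. The step that bears most on it is a 4.8-fold lower number from compound 2 to compound 3 (0.68 log units; beyond the scatter), modest and in favour of the aromatic group; the large steps of an at least 2400-fold higher number from compound 1 to compound 2 (3.38 log units; beyond the scatter) and an at least 510-fold higher number from compound 1 to compound 3 (2.70 log units; beyond the scatter) show how far the aryl variants reach. A chain in place of 4-bromophenyl is therefore expected to raise the number, a 2.9-fold higher number from compound 3 to compound 4 (0.47 log units; beyond the scatter). Compound 4 is estimated at 15000 nM, within 5000 nM to 45000 nM.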

Compound 4, half-maximal inhibitory concentration: 26300 nM
For compound 4 the middle estimate is 1.8-fold (0.24 log units) below the measured one; the measured number falls inside the stated range.
By their numbers in this assay, from the lowest: compound 3; then compounds 2 and 4 (each within the scatter of the next). At a limit, below all of these: compound 1.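

In this assay, butyl and cyclopropyl on this aromatic carbon cannot be told apart, a 1.1-fold higher number from compound 2 to compound 4 (0.03 log units; within the scatter), so the two groups without an aromatic ring now sit together, while 4-bromophenyl stands apart from butyl, a 5.2-fold higher number from compound 3 to compound 4 (0.71 log units; beyond the scatter). The distance to 4-methoxyphenyl is far greater, an at least 2600-fold higher number from compound 1 to compound 4 (3.41 log units; beyond the scatter), though that step rests on a limit and gives no exact size: the limit of < 10 nM in this assay, at which 1 of the 4 values shown sits.

The compounds shown leave open whether a longer chain or an amine in place of butyl would stay level with butyl and cyclopropyl. They also leave open whether an unsubstituted phenyl would fall nearer 4-bromophenyl or 4-methoxyphenyl.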